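Swapping the imidazole for pyrrole on compound 3's chain

A few compounds are considered here, and "the series" means these few. Any claim that something is new, unique, unknown or untested is made for them only; others in the source may bear on it.

Measured compounds:
Compound 1 `Cn1cc(C2=C(c3nn(CCCCn4ccnc4)c4ncccc34)C(=O)NC2=O)c2ccccc21` gives 23500 nM
Compound 2 `CN1CCN(CCCn2nc(C3=C(c4cn(C)c5ccccc45)C(=O)NC3=O)c3cccnc32)CC1` gives > 100000 nM
Compound 3 `Cn1cc(C2=C(c3nn(CCCn4ccnc4)c4ncccc34)C(=O)NC2=O)c2ccccc21` gives > 100000 nM

Compound 1 is the only one of the three with a numerical value in a functional assay on ECa-109 cells (Homo sapiens) for antiproliferative activity, read by MTT assay, with a stated time of 48 h (a higher number here means a weaker inhibitor, a lower number a stronger inhibitor), where compound 1 gives 23500 nM. For compound 2 the reading in this assay is only a limit, > 100000 nM. For compound 3 the reading is likewise only a limit, > 100000 nM; compound 3 therefore stands at the weak end of what is shown, at the limit of > 100000 nM in this assay, at which 2 of the 3 values shown sit.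

The step to compound 4 `Cn1cc(C2=C(c3nn(CCCn4cccc4)c4ncccc34)C(=O)NC2=O)c2ccccc21` is 1H-pyrrol-1-yl in place of 1H-imidazol-1-yl on a saturated chain carbon, three bonds along the chain from an aromatic nitrogen. Of the measured steps, an at least 4.2-fold higher number from compound 1 to compound 3 (0.62 log units; beyond the scatter) and an at least 4.2-fold higher number from compound 1 to compound 2 (0.62 log units; beyond the scatter) touch the same chain position, and both run toward weaker inhibition. Among the measured compounds shown here, none of them exchanges the imidazole ring itself for another five-membered ring, so no measured step speaks directly to this change. The group that leaves and the group that enters are of equal size, and compound 3 already sits at the limit, so the expected step, a number no higher from compound 3 to compound 4 (the limit leaves the size open), is small, with no direction predicted beyond the scatter. Compound 4 is therefore estimated at 100000 nM, within 30000 nM to 300000 nM, most likely reported only as a limit again.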

Compound 4, half-maximal inhibitory concentration: > 100000 nM
Compound 4 was reported as a limit; the forecaster's own chance of this, stated with the estimate: 60%; the middle value sits exactly at the limit.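

In this assay, putting 1H-pyrrol-1-yl in place of 1H-imidazol-1-yl on this chain gives compound 4 only a limit, not a number, as for compound 3: the limit of > 100000 nM in this assay, at which 3 of the 4 values shown sit. The steps that join compound 4 to compound 2 and compound 3 cannot be read, so this exchange has no measurable size here. Among the compounds shown here, the one readable step is an at least 4.2-fold higher number from compound 1 to compound 4 (0.62 log units; beyond the scatter), and it shows that a third end group on the 3-carbon propyl chain, 3-(1H-pyrrol-1-yl)propyl, also fails to reach the number that compound 1 gives.

The compounds shown leave open whether 1H-pyrrol-1-yl on the longer chain of compound 1 would give a number in this assay. They also leave open whether a primary amine or a carboxylic acid at the end of the propyl chain would come off the limit.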